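A few compounds are considered here, and "the series" means these few. Any claim that something is new, unique, unknown or untested is made for them only; others in the source may bear on it.

Three analogues of one core have been measured in an assay on CHO-K1 cells for displacement of a labelled ligand from adenosine receptor A1 (Homo sapiens), tested at 50 uM; on this read-out lower numbers stand for less inhibition and higher numbers for more inhibition at the one concentration tested (going by the name of the read-out). Compound 1 `CCOC(=O)c1nn(-c2ccc(C(C)(C)C)cc2)c(=O)c2c(N)scc12` gives 23%, compound 2 `CCOC(=O)c1nn(-c2ccc(O)cc2)c(=O)c2c(N)scc12` gives 65.8%, and compound 3 `CCOC(=O)c1nn(-c2ccc([N+](=O)[O-])cc2)c(=O)c2c(N)scc12` gives 73.4%, the highest of the three numbers, with compound 2 within the scatter of it and compound 1 well below it (a number 50.4 percentage points higher from compound 1 to compound 3 (beyond the scatter)). Compound 4 `CCOC(=O)c1nn(-c2ccc(OC(C)=O)cc2)c(=O)c2c(N)scc12` differs from compound 3 by acetoxy in place of nitro on an aromatic carbon. Among the measured compounds shown here, no measured step swaps nitro for acetoxy. The nearest guide is a number 7.6 percentage points higher from compound 2 to compound 3 (within the scatter), an exchange at the same aromatic carbon that stayed within the scatter, while a number 42.8 percentage points higher from compound 1 to compound 2 (beyond the scatter) and a number 50.4 percentage points higher from compound 1 to compound 3 (beyond the scatter) show that only tert-butyl at that carbon fell far. A step within the scatter, or a modest fall, is therefore expected; the expected step is a number 15.4 percentage points lower from compound 3 to compound 4 (beyond the scatter). Compound 4 is estimated at 58%, range 30% to 78%.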

Compound 4, a percentage reported as inhibition, at one concentration (the size of the read-out at that concentration, not a potency): 48.9%
Estimate against measurement, compound 4: 9.1 percentage points above; the measured number falls inside the stated range.
By their numbers in this assay, from the lowest: compound 1; then compound 4; then compounds 2 and 3 (each within the scatter of the next).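

In this assay, acetyl in place of hydrogen on the oxygen (a number 16.9 percentage points lower from compound 2 to compound 4 (beyond the scatter)) and acetoxy in place of nitro (a number 24.5 percentage points lower from compound 3 to compound 4 (beyond the scatter)) both lower the number, so this aromatic carbon separates groups beyond the hydroxy and nitro pair, whose values lay within the scatter. Acetoxy in place of tert-butyl (a number 25.9 percentage points higher from compound 1 to compound 4 (beyond the scatter)) places acetoxy at an intermediate level. Nothing available explains these steps.

Still open, from the compounds shown here alone, is where an amine, a carboxylic acid or a longer acyl chain on that oxygen would fall at this carbon.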